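A Dichlorophenyl Replaces Naphthalen-1-yl on the Ring Nitrogen

This account rests on a few compounds, and the source may have more. Where it says the series, first, only, none or still open, it means among the compounds named here.

Of the compounds shown here, three sharing one core have been measured in a functional assay on CHO cells with adenosine receptor A1 (Homo sapiens) as the target, read by cAMP accumulation and immunoassay, with a stated time of 6 min, tested at 0.1 uM; a lower number here means a stronger effect, a higher number a weaker effect of the compound at the concentration tested. Compound 1 `Nc1scc(CN2CCN(c3ccc(OC(F)(F)F)cc3)CC2)c1C(=O)c1ccc(Cl)cc1` gives -13%, compound 2 `Nc1scc(CN2CCN(c3ccc(C(F)(F)F)cc3)CC2)c1C(=O)c1cccc(C(F)(F)F)c1` gives -11%, and compound 3 `Nc1scc(CN2CCN(c3cccc4ccccc34)CC2)c1C(=O)c1ccc(Cl)cc1` gives 0%, the highest of the three and beyond the scatter from both others. Compound 4 `Nc1scc(CN2CCN(c3cc(Cl)ccc3Cl)CC2)c1C(=O)c1ccc(Cl)cc1` has not yet been measured; it differs from compound 3 by 2,5-dichlorophenyl in place of naphthalen-1-yl on an amine nitrogen in a ring. Among the compounds with values here, one measured step bears on this change at the same ring nitrogen: a number 13 percentage points higher from compound 1 to compound 3 (beyond the scatter). Because a number 13 percentage points higher from compound 1 to compound 3 (beyond the scatter) came with naphthalen-1-yl replacing a substituted phenyl, a modest downward step is expected now that a substituted phenyl returns, although the dichlorophenyl itself is new here. Compound 4 is therefore estimated at -8%, within -22% to 8%, an expected step of a number 8 percentage points lower from compound 3 to compound 4 (within the scatter).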

Compound 4, a percentage reported as activity, at one concentration (the size of the read-out at that concentration, not a potency): -6.2%
The estimate for compound 4 lay 1.8 percentage points below the measured number; the measured number falls inside the stated range.
By their numbers in this assay, from the lowest: compounds 1, 2, 4 and 3 (each within the scatter of the next, the first and the last beyond it).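

In this assay, 2,5-dichlorophenyl on the ring nitrogen cannot be told apart from naphthalen-1-yl (a number 6.2 percentage points lower from compound 3 to compound 4 (within the scatter)). Nor can it be told apart from 4-(trifluoromethoxy)phenyl (a number 6.8 percentage points higher from compound 1 to compound 4 (within the scatter)), even though those two groups differ beyond the scatter, so compound 4 cannot be ranked against either. No evidence here accounts for these results.

The compounds shown leave open whether a phenyl with a single chlorine would read like the dichlorophenyl. They also leave open how a phenyl carrying a carboxylic acid or an amine would read at this ring nitrogen.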